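Isopropylamino in Place of Methylamino on the Shared Core

The compounds below may be only part of what the source reports. "The series", "measured", "known", "first", "only" and "open" are said of these compounds alone.

Compound 1 `Cc1noc(NS(=O)(=O)c2cccc3ccccc23)c1C`: 20000 nM
Compound 2 `CNc1cccc2c(S(=O)(=O)Nc3onc(C)c3C)cccc12`: 130 nM

For the measured compounds named here, in an assay on VSM-A10 cells for antagonist activity at Endothelin-1 receptor (Rattus norvegicus) (on this read-out higher numbers stand for weaker inhibition and lower numbers for stronger inhibition), compound 1 gives 20000 nM, and compound 2 gives 130 nM, the lowest of the two numbers known here. Going by the values given here, the only measured step is a 150-fold lower number from compound 1 to compound 2 (2.19 log units; beyond the scatter), which came with methylamino in place of hydrogen on an aromatic carbon. Compound 3 `Cc1noc(NS(=O)(=O)c2cccc3c(NC(C)C)cccc23)c1C` keeps that substituted nitrogen and differs from compound 2 by isopropyl in place of methyl on a nitrogen on an aromatic ring. Among the compounds with values here, no measured step addresses a change of the alkyl group on this nitrogen; the step from compound 1 to compound 2 shows only that the presence of the alkylamino group matters a great deal. Without a comparable step, the expected change is small, in either direction, and an estimated step of a 1.1-fold lower number from compound 2 to compound 3 (0.03 log units; within the scatter) within the scatter is the reasonable expectation. Compound 3 is thus estimated at 120 nM in this assay, with a range of 35 nM to 450 nM.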

Compound 3, half-maximal inhibitory concentration: 20 nM
Compound 3: the middle estimate sits 6.0-fold (0.78 log units) above what was measured; measured number below the stated range.
By their numbers in this assay, from the lowest: compound 3; then compound 2; then compound 1.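

In this assay, the alkyl group on this nitrogen turns out to matter in its own right, not just the presence of the substituted nitrogen: methylamino to isopropylamino gives a 6.5-fold lower number from compound 2 to compound 3 (0.81 log units; beyond the scatter). Set against hydrogen on the aromatic carbon, the isopropylamino group brings a 1000-fold lower number from compound 1 to compound 3 (3.00 log units; beyond the scatter), so the size of the gain at this position depends on which alkyl group the nitrogen carries. No supporting data are available to explain this difference.

The three compounds leave open whether the number keeps falling with a tert-butyl or cyclohexyl group on this nitrogen, or rises again with a longer chain. They also leave open whether the hydrogen on this nitrogen is needed, which a dimethylamino group would test, and whether an ether oxygen could stand in place of the nitrogen.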